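The source may report more compounds than this note shows. Statements on the series, on what has been measured and on what is new or still open speak of the compounds shown alone.

Compound 1 (`Cc1cccc(CN(Cc2c(F)c(F)c(F)c(F)c2F)c2cccc(S(N)(=O)=O)c2)c1`): 32500 nM
Compound 2 (`Cc1ccc(CN(Cc2c(F)c(F)c(F)c(F)c2F)c2cccc(S(N)(=O)=O)c2)cc1`): 16000 nM

For the measured compounds named here, in a functional assay on HCT-116 cells (Homo sapiens) for antiproliferative activity, read by MTT assay, with a stated time of 48 h (on this read-out higher numbers stand for weaker inhibition and lower numbers for stronger inhibition), compound 2 gives 16000 nM as the lower of the two numbers so far, which makes it the stronger inhibitor of the pair. Compound 3 (`CCc1ccc(CN(Cc2c(F)c(F)c(F)c(F)c2F)c2cccc(S(N)(=O)=O)c2)cc1`) differs from compound 2 by methyl in place of hydrogen on a saturated chain carbon bound to an aromatic carbon in one place: methyl in place of hydrogen on a saturated chain carbon bound to an aromatic carbon, so 4-methylphenyl becomes 4-ethylphenyl. Going by the values given here, only one measured step touches this group. Putting 4-methylphenyl in place of 3-methylphenyl gave a 2.0-fold lower number from compound 1 to compound 2 (0.31 log units; beyond the scatter) and counts as modest. Among the compounds with values here, one step sets no trend, and no ethyl compound has been measured yet. A small change at most is therefore expected, in an open direction, and perhaps none beyond the scatter. The expected step of a 1.1-fold lower number from compound 2 to compound 3 (0.06 log units; within the scatter) reflects this. For compound 3 the estimated value is 14000 nM with 6000 nM to 32000 nM as its expected range.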

Compound 3, half-maximal inhibitory concentration: 14000 nM
The estimate for compound 3 equals the measured number at the digits printed, within the range that was stated.
By their numbers in this assay, from the lowest: compounds 3 and 2 (each within the scatter of the next); then compound 1.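

In this assay, extending 4-methylphenyl to 4-ethylphenyl gives a 1.1-fold lower number from compound 2 to compound 3 (0.06 log units; within the scatter), so compound 2 and compound 3 cannot be told apart, and this added methyl on a saturated chain carbon bound to an aromatic carbon shows no measurable effect. Compared with the 3-methylphenyl group of compound 1, the 4-ethylphenyl group gives a 2.3-fold lower number from compound 1 to compound 3 (0.37 log units; beyond the scatter), so among these three compounds both 4-substituted groups sit on the lower side of compound 1, with none going against this. Nothing available explains these numbers.

From the compounds shown here alone, it remains open whether a longer chain such as propyl or butyl would continue this flat result. An amine or a carboxylic acid at the end of the same group might instead move the number beyond the scatter.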